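Piperidine substituent series: aromatic ring replaces ester

A few compounds are considered here, and "the series" means these few. Any claim that something is new, unique, unknown or untested is made for them only; others in the source may bear on it.

Three compounds share one core and differ only in the group on a saturated ring carbon. In a functional assay on the whole organism for inhibition, with Rattus norvegicus as the target, read by paw edema, with stated times of 4 days, 1 h and 2 h, at a dose of 100 mg/kg by the oral route (a higher number here means more inhibition at the dose given (going by the name of the read-out), a lower number less inhibition), compound 1 `CC1CCN(c2nc(-c3ccccc3)nc3ccccc23)CC1` gives 69%, compound 2 `c1ccc(-c2nc(N3CCC(c4ccccc4)CC3)c3ccccc3n2)cc1` gives 85.3% and compound 3 `CCOC(=O)C1CCN(c2nc(-c3ccccc3)nc3ccccc23)CC1` gives 70.3%. Compound 3 stands second highest of the three numbers; its nearest neighbour is compound 1, within the scatter, and the furthest is compound 2, which is beyond the scatter above it.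

The next compound, compound 4 `S=c1[nH]nc(C2CCN(c3nc(-c4ccccc4)nc4ccccc34)CC2)s1`, differs from compound 3 by a group of 6 heavy atoms (2 carbon, 2 nitrogen, 2 sulfur; one five-membered aromatic ring with 3 hetero atoms) in place of a group of 5 heavy atoms (3 carbon, 2 oxygen; no ring), on a saturated ring carbon.

Among the measured compounds shown here, two measured steps bear on this change. Putting an aromatic ring in place of a small group on this carbon gave a number 16.3 percentage points higher from compound 1 to compound 2 (beyond the scatter), while exchanging that aromatic ring for the ester gave a number 15 percentage points lower from compound 2 to compound 3 (beyond the scatter). The step of a number 1.3 percentage points higher from compound 1 to compound 3 (within the scatter) shows that methyl and ethoxycarbonyl sit together within the scatter. Compound 4 again carries an aromatic ring on this carbon, so the direction of a number 16.3 percentage points higher from compound 1 to compound 2 (beyond the scatter) is the better analogy and a modest rise in this assay is expected, not a fall.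

For compound 4 the expected value is 78%, with a likely range from 63% to 90%, meaning an expected step of a number 7.7 percentage points higher from compound 3 to compound 4 (within the scatter).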

Compound 4, a percentage reported as inhibition, in the whole organism at one dose (the size of the read-out at that dose, not a potency): 71.3%
The estimate for compound 4 lay 6.7 percentage points above the measured number; the measured number falls inside the stated range.
By their numbers in this assay, from the lowest: compounds 1, 3 and 4 (each within the scatter of the next); then compound 2.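

In this assay, an aromatic ring on this saturated ring carbon does not by itself carry the higher number: the five-membered aromatic ring with 3 hetero atoms, in place of phenyl, gives a clear drop (a number 14 percentage points lower from compound 2 to compound 4 (beyond the scatter)). The same group stands level with both the ester (a number 1 percentage points higher from compound 3 to compound 4 (within the scatter)) and methyl (a number 2.3 percentage points higher from compound 1 to compound 4 (within the scatter)), so three quite different groups, one small and without a ring, one an open ester and one a heteroaromatic ring, cannot be told apart here, and among the four compounds only the phenyl of compound 2 stands apart from the rest. No measurement at hand accounts for the separate standing of phenyl, or for the level standing of the other three groups.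

The compounds shown leave open whether the higher number belongs to phenyl alone or extends to a phenyl ring carrying chlorine or methoxy, to benzyl, or to a six-membered aromatic ring with a ring nitrogen. They also leave open what an amine or a carboxylic acid on this carbon would give in this assay.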